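The source may report more compounds than this note shows. Statements on the series, on what has been measured and on what is new or still open speak of the compounds shown alone.

Two compounds in the series carry measured values. Compound 1 `O=S(=O)(NCCCNCc1ccc(Cl)c(C(F)(F)F)c1)c1cc(C(F)(F)F)cc(C(F)(F)F)c1` and compound 2 `CN(CCCNS(=O)(=O)c1cc(C(F)(F)F)cc(C(F)(F)F)c1)Cc1ccccc1` share the same core and differ only at the far end of the chain. In a functional assay on ASPC1 cells (Homo sapiens) for inhibition, read by MTT assay, with a stated time of 72 h (on this read-out higher numbers stand for weaker inhibition of growth and lower numbers for stronger inhibition of growth), compound 1 gives 9600 nM, and in this assay compound 2 gives 51000 nM, the higher of the two numbers, separated from compound 1 by a gap beyond the scatter. Compound 3 `O=S(=O)(NCCCNCc1ccc(Br)cc1)c1cc(C(F)(F)F)cc(C(F)(F)F)c1` is to be measured in this assay. Relative to compound 2 the change is (4-bromobenzyl)amino in place of benzyl(methyl)amino on a saturated chain carbon, three bonds along the chain from a sulfonamide nitrogen. Among the measured compounds shown here, no measured pair isolates this change. Compound 3 resembles compound 1 more closely than compound 2 does, the amine carrying a hydrogen rather than a methyl and the benzyl ring a halogen. A drop beyond the scatter is expected for a 3.4-fold lower number from compound 2 to compound 3 (0.53 log units; beyond the scatter), because compound 1 gives 9600 nM. Compound 3 is estimated at 15000 nM, within 5000 nM to 45000 nM.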

Compound 3, concentration for 50% growth inhibition: 2800 nM
The estimate for compound 3 lay 5.4-fold (0.73 log units) above the measured number; measured number outside the range, below it.
By their numbers in this assay, from the lowest: compound 3; then compound 1; then compound 2.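

In this assay, (4-bromobenzyl)amino in place of benzyl(methyl)amino gives an 18-fold lower number from compound 2 to compound 3 (1.26 log units; beyond the scatter), so the group on this saturated chain carbon can shift growth inhibition substantially. With the amine hydrogen kept, 4-bromophenyl in place of 4-chloro-3-(trifluoromethyl)phenyl gives a 3.4-fold lower number from compound 1 to compound 3 (0.54 log units; beyond the scatter), a modest step showing that the ring substituents alone matter and placing compound 3 as the most potent of the three. Nothing available explains either step.

The step to compound 3 changes the amine methyl and the ring bromine together, so the share of each remains unresolved; the unsubstituted benzylamino group and the N-methyl-4-bromobenzylamino group would separate them. As far as these compounds go, whether other ring groups, such as 4-methoxybenzyl, or a longer chain between the sulfonamide and the amine would hold this level of inhibition also remains open.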